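Amine branching at the shared core: extending 1-methylbutyl to 1-propylbutyl

The source may hold more compounds than are shown below. What is called first, only, known or untested is meant among the compounds shown, and "the series" means these compounds.

Measured compounds:
compound 1 `CCCCN(CC)c1nc(C)nc2c1nnn2-c1c(C)cc(C)cc1C` — 27.5 nM in an in vitro assay on 293-EBNA cells for binding affinity to corticotropin-releasing factor receptor 1 (Homo sapiens); a lower number here means a stronger inhibitor, a higher number a weaker inhibitor
compound 2 `COCCNc1nc(C)nc2c1nnn2-c1c(C)cc(C)cc1C` — compound 2 gives 1200 nM in this assay
compound 3 `CCCC(C)Nc1nc(C)nc2c1nnn2-c1c(C)cc(C)cc1C` — compound 3 gives 7.1 nM in this assay

Compound 3 stands lowest of the three numbers: a 3.9-fold lower number from compound 1 to compound 3 (0.59 log units; beyond the scatter); and a 170-fold lower number from compound 2 to compound 3 (2.23 log units; beyond the scatter). The remaining pair shows a 44-fold higher number from compound 1 to compound 2 (1.64 log units; beyond the scatter).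

Compound 4 `CCCC(CCC)Nc1nc(C)nc2c1nnn2-c1c(C)cc(C)cc1C` differs from compound 3 by ethyl in place of hydrogen on a saturated chain carbon, two bonds along the chain from a nitrogen on an aromatic ring. Among the measured compounds shown here, no measured step repeats this exact change. The steps that come closest are those at the amine: from compound 1 to compound 3 the branched (1-methylbutyl)amino gave a modest lower number, and from compound 2 to compound 3 the change from 2-methoxyethyl to 1-methylbutyl gave a large lower number. Both point to larger branched alkyl groups on that nitrogen being tolerated or favoured within this small set, but neither tells how a further ethyl on the branch carbon will read.

Expectation: in this assay compound 4 is estimated at 5 nM, range 1.5 nM to 20 nM; the expected step of a 1.4-fold lower number from compound 3 to compound 4 (0.15 log units; within the scatter) is small, most likely within the scatter or a slight lowering.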

Compound 4, inhibition constant: 4 nM
The estimate for compound 4 lay 1.3-fold (0.10 log units) above the measured number; the range from low to high includes it.
By their numbers in this assay, from the lowest: compounds 4 and 3 (each within the scatter of the next); then compound 1; then compound 2.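

In this assay, ethyl in place of hydrogen on a saturated chain carbon, two bonds along the chain from a nitrogen on an aromatic ring, gives a 1.8-fold lower number from compound 3 to compound 4 (0.25 log units; within the scatter), so this position accepts the change from 1-methylbutyl to 1-propylbutyl without a step beyond the scatter. The larger branched group also keeps the separation from the other two amines, with a 6.9-fold lower number from compound 1 to compound 4 (0.84 log units; beyond the scatter) and a 300-fold lower number from compound 2 to compound 4 (2.48 log units; beyond the scatter), the first modest and the second large. Nothing in the available data accounts for these numbers, and the reading stays purely descriptive.

Open, on these data alone, is whether the same position would also accept a longer chain on the branch carbon, as in 1-butylpentyl, or a ring on the nitrogen, as in cyclopentylamino, and whether either would give a step beyond the scatter from compound 4. Also open, as far as these compounds go, is how a methoxy group would read on a branched chain such as 1-(methoxymethyl)propyl, since the compounds here carry methoxy only in 2-methoxyethyl, on the unbranched amine of compound 2.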